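The source may report more compounds than this note shows. Statements on the series, on what has been measured and on what is new or still open speak of the compounds shown alone.

Compound 1 `CCCCCCCCCCCCCCCCn1cc(COC[C@@H]2OC[C@H](N)[C@@H]2O)nn1` and compound 2 `CCCCCCCCCCCCCCCCCCn1cc(COC[C@@H]2OC[C@H](N)[C@@H]2O)nn1` are built on the same core and differ in one place only: ethyl in place of hydrogen on a saturated chain carbon, ten or more bonds along the chain from an aromatic nitrogen. In a functional assay on MGC-803 cells (Homo sapiens) for antiproliferative activity, read by MTT assay, with a stated time of 48 h (a lower number here means a stronger inhibitor, a higher number a weaker inhibitor), compound 1 gives 27900 nM, while compound 2 gives 15400 nM, so that the change produced a 1.8-fold lower number from compound 1 to compound 2 (0.26 log units; within the scatter). Compound 3 `CCCCCCCCCCn1cc(COC[C@@H]2OC[C@H](N)[C@H]2O)nn1` stands on a core whose difference from the core of compound 1 is not broken down here; in this assay compound 3 gives 57400 nM, the highest of the three numbers. Compound 4 `CCCCCCCCCCCCn1cc(COC[C@@H]2OC[C@H](N)[C@H]2O)nn1` carries the same change made from compound 3, namely (ethyl in place of hydrogen on a saturated chain carbon, ten or more bonds along the chain from an aromatic nitrogen), in the same place. Because the earlier step was a 1.8-fold lower number from compound 1 to compound 2 (0.26 log units; within the scatter), a step of similar size is expected here, a 1.9-fold lower number from compound 3 to compound 4 (0.28 log units; within the scatter). For compound 4 in this assay the estimated value is 30000 nM.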

Compound 4, half-maximal inhibitory concentration: 115000 nM
For compound 4 the middle estimate is 3.8-fold (0.58 log units) below the measured one; the measured number lies above the stated range.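

In this assay the swap of hydrogen for ethyl gives a 2.0-fold higher number from compound 3 to compound 4 (0.30 log units; within the scatter) on this core. Taken alone, each of the two steps is too small to read as a real change, and two pairs give no rule for what this swap does on other cores, nor do they show which part of the cores matters. Set side by side, however, the two steps show that the effect of the swap does not carry over unchanged from one core to the other: the same change on two cores in this assay, a 1.8-fold lower number (0.26 log units; within the scatter) from compound 1 to compound 2 and a 2.0-fold higher number (0.30 log units; within the scatter) from compound 3 to compound 4, 3.6-fold (0.56 log units) apart, beyond the scatter of two such steps

On these data alone, it remains open whether the same gap would appear on further cores. Also open, as far as these compounds go, is how the series would respond to a longer chain, or to a chain carrying a carboxylic acid.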